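The source may hold more compounds than are shown below. What is called first, only, known or untested is meant among the compounds shown, and "the series" means these compounds.

Working notes on the series.

The shared core is carried by compound 1 `CC1=C(C(=O)Nc2ccc([N+](=O)[O-])cc2)C(c2ccc(Br)cc2)N=C(SCc2ccccc2)N1` and compound 2 `CC1=C(C(=O)Nc2ccc([N+](=O)[O-])cc2)C(c2ccc(Br)cc2)N=C(SCc2ccc(F)cc2)N1`, both tested in a functional assay on the whole organism (artery, strain albino) with Rattus norvegicus as the target, with a stated time of 900 min, at a dose of 10 mg/kg by the oral route; on this read-out lower numbers stand for less inhibition and higher numbers for more inhibition at the one dose given (going by the name of the read-out). In this assay compound 1 gives 19.5%, and compound 2 gives 22.6%. Going by the values given here, the two numbers lie within the scatter of each other, so no ranking between compound 1 and compound 2 is drawn; the single measured step, a number 3.1 percentage points higher from compound 1 to compound 2 (within the scatter), is a fluoro in place of hydrogen on an aromatic carbon of the benzylsulfanyl group and says nothing beyond the scatter.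

Compound 3 `CC1=C(C(=O)Nc2ccc([N+](=O)[O-])cc2)C(c2cccc([N+](=O)[O-])c2)N=C(SCc2ccccc2)N1` has not been measured in this assay. It differs from compound 1 as follows: 3-nitrophenyl in place of 4-bromophenyl on a saturated ring carbon. Among the compounds with values here, the change sits on the saturated ring carbon of the core, a position not touched by the step from compound 1 to compound 2, so no measured step bears on it, and the size or direction of the effect cannot be read from the data.

With nothing to pull the number away from compound 1, compound 3 is expected to give about 20% in this assay, with a wide range from 5% to 40%. The expected step is therefore a number 0.5 percentage points higher from compound 1 to compound 3 (within the scatter), within the scatter, though the uncertainty is large.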

Compound 3, a percentage reported as inhibition, in the whole organism at one dose (the size of the read-out at that dose, not a potency): 14.9%
The estimate for compound 3 lay 5.1 percentage points above the measured number; measured number inside the range.
By their numbers in this assay, from the lowest: compounds 3, 1 and 2 (each within the scatter of the next).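

In this assay the saturated ring carbon of the shared core now has a measured change of its own: 3-nitrophenyl in place of 4-bromophenyl gives a number 4.6 percentage points lower from compound 1 to compound 3 (within the scatter) and so sets neither compound above the other. Going from 4-bromophenyl to 3-nitrophenyl changes both the group on the phenyl ring and its place on that ring, so this single step cannot separate the two changes, and the compounds shown give no step beyond the scatter at this carbon. Nothing at hand bears on why the number falls where it does.

The compounds shown leave open whether 3-bromophenyl or 4-nitrophenyl, each of which would change only one of those two features, would read differently from compound 1 or compound 3. They also leave open whether a carboxylic acid or an amine on this phenyl ring, or a simple alkyl chain in place of the ring, would move the read-out beyond the scatter in this assay at this dose.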